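Chloro to 4-methylpiperazin-1-yl: working notes on compound 3

The compounds below may be only part of what the source reports. "The series", "measured", "known", "first", "only" and "open" are said of these compounds alone.

Measured in a functional assay on A2780 cells (Homo sapiens) for cytotoxicity, read by MTT assay, with a stated time of 48 h; a lower number here means a stronger inhibitor, a higher number a weaker inhibitor:
- compound 1 `CCn1cc(-c2nc3ccccc3o2)c(=O)c2cc(F)c(N3CCN(C)CC3)cc21`: 700 nM
- compound 2 `CCn1cc(-c2nc3ccc([N+](=O)[O-])cc3o2)c(=O)c2cc(F)c(Cl)cc21`: "not determined" (no result reported)

Within the data shown here, compound 2 has no single number in this assay and therefore offers no baseline for the step. Compound 3 `CCn1cc(-c2nc3ccc([N+](=O)[O-])cc3o2)c(=O)c2cc(F)c(N3CCN(C)CC3)cc21` is the next structure to be measured. The change is 4-methylpiperazin-1-yl in place of chloro on an aromatic carbon, ortho to a fluoro group. The size of this step cannot be read from compound 2 itself. Among the measured compounds shown here, the only measured compound with the 4-methylpiperazin-1-yl group is compound 1 at 700 nM, so a result for compound 3 near that value is expected, with no shift in either direction beyond the usual scatter. For compound 3 the estimate is 600 nM, with the result expected between 150 nM and 2000 nM.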

Compound 3, half-maximal inhibitory concentration: 39600 nM
For compound 3 the middle estimate is 66-fold (1.82 log units) below the measured one; measured number outside the range, above it.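

In this assay, with the 4-methylpiperazin-1-yl group held constant, nitro in place of hydrogen on an aromatic carbon gives a 57-fold higher number from compound 1 to compound 3 (1.75 log units; beyond the scatter) and this large step lies beyond the scatter. The 4-methylpiperazin-1-yl group therefore does not set the number on its own, and the group at the nitro-bearing carbon matters strongly, which compound 1 alone could not show. The step from chloro to 4-methylpiperazin-1-yl cannot be read, as compound 2 has no number, and nothing available explains the effect of the nitro group.

The compounds shown leave open whether an amine or a methoxy group on that same carbon would follow nitro or hydrogen. Also open, going by these compounds, is whether morpholine or piperidine in place of 4-methylpiperazin-1-yl would shift the number on either core.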